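A Methyl Added to the Core of Compound 3

The compounds below may be only part of what the source reports. "The series", "measured", "known", "first", "only" and "open" are said of these compounds alone.

Three compounds that share a 2,6-dichlorobenzyl group on a five-membered aromatic ring were tested in an assay on CHO cells, read by calcium flux; a lower number here means a stronger inhibitor, a higher number a weaker inhibitor. Compound 1 `CC(C)c1ccc(NC(=O)c2csc(Cc3c(Cl)cccc3Cl)n2)cc1` gives 370 nM in this assay. Compound 2 `O=C(Nc1ccc(C(F)(F)F)nc1)c1csc(Cc2c(Cl)cccc2Cl)n1` gives 110 nM in this assay. Compound 3 `O=C(Nc1ccc(C(F)(F)F)cc1)c1cnc(Cc2c(Cl)cccc2Cl)s1` gives 790 nM in this assay, the highest number of the three; its distance to compound 1 and its distance to compound 2 both lie beyond the scatter, so compound 3 is the weakest inhibitor of the three measured.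

Compound 4 `Cc1nc(Cc2c(Cl)cccc2Cl)sc1C(=O)Nc1ccc(C(F)(F)F)cc1` differs from compound 3 in a single place: methyl in place of hydrogen on an aromatic carbon. For the measured compounds named here, no pair of measured compounds shows this same change, so the data give no direct guide to its effect. The change adds one carbon and nothing else, and the expected step of a 1.1-fold lower number from compound 3 to compound 4 (0.05 log units; within the scatter) is one that stays within the usual scatter, in no clear direction. Compound 4 is therefore expected to give about 700 nM in this assay, with a likely range from 250 nM to 2000 nM.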

Compound 4, half-maximal inhibitory concentration: 3420 nM
Compound 4: the middle estimate sits 4.9-fold (0.69 log units) below what was measured; measured number outside the range, above it.
By their numbers in this assay, from the lowest: compound 2; then compound 1; then compound 3; then compound 4.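

This carbon, next to the ring nitrogen and next to the ring atom that bears a large group, does not tolerate change freely: in this assay, replacing hydrogen with methyl gives a 4.3-fold higher number from compound 3 to compound 4 (0.64 log units; beyond the scatter). A higher number means a weaker inhibitor. Adding a single carbon here clearly weakens inhibition, even though compound 3 already had the highest number of the first three compounds. Nothing available explains why this one carbon has such an effect.

As far as these compounds go, it remains open whether the loss is specific to methyl, or whether a fluorine, a chlorine, an ethyl group or an amine on this carbon would give a similar step. Among the compounds shown, this change appears in only one pair, so its effect on the cores of compound 1 and compound 2 also remains open.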